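The compounds below may be only part of what the source reports. "The series", "measured", "known", "first", "only" and "open" are said of these compounds alone.

Compound 1, `O=C(CN1CCCC1)OC1CC2(N3CCCCC3)CC(c3ccccc3)C1C(c1ccccc1)C2`, gives 16400 nM in an ADME assay on L6 cells (Rattus norvegicus) for cytotoxicity, read by resazurin assay, with a stated time of 72 h (a higher number here means a weaker inhibitor, a lower number a stronger inhibitor), and holds the lowest of the two numbers in hand. For the measured compounds named here, compound 2, `CN1CCN(CCC(=O)NC2CC3(N(C)C)CC(c4ccccc4)C2C(c2ccccc2)C3)CC1`, gives 95000 nM in this assay, a higher number that lies beyond the scatter; the two compounds differ in more than one place, so the pair shows only that their values lie apart. Compound 3, `CN1CCN(CC(=O)OC2CC3(N4CCCCC4)CC(c4ccccc4)C2C(c2ccccc2)C3)CC1`, has not yet been measured. Against compound 1 it carries this change: 4-methylpiperazin-1-yl in place of pyrrolidin-1-yl on a saturated chain carbon bound to a carbonyl carbon. Going by the values given here, no measured step covers this exact exchange. The expectation can rest only on compound 2, which also carries a 4-methylpiperazin-1-yl group and in this assay gives 95000 nM, a higher number, though other parts of compound 2 differ as well. A modest rise of the number is expected, a 1.6-fold higher number from compound 1 to compound 3 (0.20 log units; within the scatter), smaller than the gap compound 2 showed. Compound 3 is therefore expected at 26000 nM in this assay, with a range of 10000 nM to 70000 nM.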

Compound 3, half-maximal inhibitory concentration: 29500 nM
Compound 3: the middle estimate sits 1.1-fold (0.05 log units) below what was measured; the range from low to high includes it.
By their numbers in this assay, from the lowest: compounds 1 and 3 (each within the scatter of the next); then compound 2.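

At the saturated chain carbon bound to a carbonyl carbon, 4-methylpiperazin-1-yl in place of pyrrolidin-1-yl gives a 1.8-fold higher number from compound 1 to compound 3 (0.25 log units; within the scatter), so the two groups are not told apart at this place in this assay. Compound 2, at 95000 nM, carries the same 4-methylpiperazin-1-yl group, but this step gives no sign that the group alone accounts for the distance of compound 2 from compound 1. No measurement is at hand that bears on the reason for this result.

Open, from the compounds shown here alone, is whether morpholin-4-yl or a longer chain between the carbonyl and the ring amine would give a step beyond the scatter. For the compounds shown here, also open is how the other differences in compound 2 contribute, since no single-place step isolates any of them.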